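Dimethylamino to phenyl on the shared core

The source may hold more compounds than are shown below. What is called first, only, known or untested is meant among the compounds shown, and "the series" means these compounds.

In a functional assay on Huh7.5.1 cells (Homo sapiens) for cytotoxicity, read by MTT assay, with a stated time of 72 h (a higher number here means that more compound is tolerated, a lower number that less compound is tolerated), compound 3 (`C=c1[nH]c(=O)/c(=C/c2ccc(N(C)C)cc2)[nH]c1=O`) gives > 20000 nM as a limit and not a number. Compound 1 (`C=c1[nH]c(=O)/c(=C/c2ccc(C(C)(C)C)cc2)[nH]c1=O`) gives > 20000 nM as a limit too. Compound 2 (`C=c1[nH]c(=O)/c(=C/c2ccc(C)cc2)[nH]c1=O`) likewise gives > 20000 nM as a limit. Compound 4 (`C=c1[nH]c(=O)/c(=C/c2ccc(-c3ccccc3)cc2)[nH]c1=O`) carries phenyl in place of dimethylamino on an aromatic carbon. For the measured compounds named here, two measured steps bear most directly on this change: a step that the two limits leave unreadable from compound 1 to compound 3 and a step that the two limits leave unreadable from compound 2 to compound 3. Going by the values given here, neither has a readable size, and the series so far shows only the limit of > 20000 nM in this assay, at which 3 of the 3 values shown sit, as its common result. No clear direction can be drawn, so an estimated step that the limit leaves unreadable from compound 3 to compound 4 is expected to stay within the scatter. The expected value for compound 4 is 25000 nM within a range of 12000 nM to 50000 nM and may again be only a limit.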

Compound 4, half-maximal cytotoxic concentration: > 20000 nM
Compound 4 was reported as a limit; the forecaster's own chance of this, stated with the estimate: 80%; the middle value lies beyond the limit too.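

In this assay compound 4 gives > 20000 nM, a limit and not a number. The steps to compound 4 from compound 1, compound 2 and compound 3 cannot be read. The compounds shown leave open whether tert-butyl, methyl, dimethylamino and phenyl differ at all in tolerated concentration.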